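This account rests on a few compounds, and the source may have more. Where it says the series, first, only, none or still open, it means among the compounds named here.

Three compounds have been measured in a functional assay on HeLa cells (Homo sapiens) for inhibition, read by CCK-8 assay, with a stated time of 72 h, tested at 2 uM; a higher number here means more inhibition of growth at the concentration tested, a lower number less inhibition of growth:

Compound 1 `Nc1ccccc1NC(=O)c1ccc(CSc2ccc(Br)cc2)cc1`: 18.8%
Compound 2 `Nc1ccccc1NC(=O)/C=C/c1ccc(CSc2ccc(Cl)cc2)cc1`: 1.94%
Compound 3 `COc1ccc(SCc2ccc(C(=O)Nc3ccccc3N)cc2)cc1`: 35%

Compound 2 stands lowest of the three, and both other values lie beyond the scatter above it. Compound 4 `Nc1ccccc1NC(=O)/C=C/c1ccc(CSc2ccc(C(F)(F)F)cn2)cc1` is not yet measured. It differs from compound 2 in one place: 5-(trifluoromethyl)pyridin-2-yl in place of 4-chlorophenyl on a sulfur. Going by the values given here, compounds 2 and 4 share a core that is not the core of compounds 1 and 3, so no measured step touches that core directly. Among the compounds with values here, the only measured step that bears on a change at the ring attached to sulfur is a number 16.2 percentage points higher from compound 1 to compound 3 (beyond the scatter), a swap of a single group on that ring. The step from compound 2 to compound 4 replaces the whole ring, which is a larger change than that one, and the known step does not tell whether a ring with a hetero atom behaves like the methoxy case or the bromo case. The expectation is therefore a small rise in this assay or no change beyond the scatter. The step from compound 2 to compound 4 is estimated at a number 6.1 percentage points higher from compound 2 to compound 4 (within the scatter). Compound 4 is expected to give 8%, within a range of 0% to 25%.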

Compound 4, percent growth inhibition at one concentration: 6.07%
Beside the measured number, compound 4's estimate is 1.9 percentage points above it; the measured number falls inside the stated range.
By their numbers in this assay, from the lowest: compounds 2 and 4 (each within the scatter of the next); then compound 1; then compound 3.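

In this assay, going by these compounds alone, putting 5-(trifluoromethyl)pyridin-2-yl in place of 4-chlorophenyl on the sulfur gives a number 4.1 percentage points higher from compound 2 to compound 4 (within the scatter), the first measured change at this place on the core shared by compound 2 and compound 4. So replacing the whole ring, which adds a hetero atom, a hydrogen-bond acceptor and more heavy atoms, does not shift the reading beyond the usual scatter, whereas the single-group swap on the other core gave a number 16.2 percentage points higher from compound 1 to compound 3 (beyond the scatter). Nothing available explains this result or says why the two steps differ in size.

As far as these compounds go, the nitrogen in the ring and the trifluoromethyl group enter together, so their separate contributions remain unknown; a plain pyridin-2-yl group or a 4-(trifluoromethyl)phenyl group on the sulfur would be needed to tell them apart. From the compounds shown here alone, it also remains open whether a quite different group on this ring, such as an amine or a carboxylic acid, would lift the number in this assay beyond the scatter on this core, or whether the methoxy group that marks compound 3 would do so here.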